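Swapping the Chlorophenyl Arm for a Styryl Group

This account rests on a few compounds, and the source may have more. Where it says the series, first, only, none or still open, it means among the compounds named here.

Compound 2 `Cc1cc(O)c(C2=NN(c3ccc(S(N)(=O)=O)cc3)C(c3ccccc3Cl)C2)cc1Cl` gives 1740 nM in a functional assay on OVCAR-5 cells (Homo sapiens) for antiproliferative activity, with a stated time of 48 h (a higher number here means a weaker inhibitor of growth, a lower number a stronger inhibitor of growth), numerically the higher of the two numbers shown yet within the scatter of compound 1 `Cc1cc(O)c(C2=NN(c3ccc(S(N)(=O)=O)cc3)C(c3ccccc3O)C2)cc1Cl`, which gives 1730 nM. For the measured compounds named here, the only measured step, a 1.0-fold higher number from compound 1 to compound 2 (0.00 log units; within the scatter), exchanges one aromatic substituent for another and does not bear on the change now considered. Compound 3 `Cc1cc(O)c(C2=NN(c3ccc(S(N)(=O)=O)cc3)C(/C=C/c3ccccc3)C2)cc1Cl` differs from compound 2 by 2-phenylethenyl in place of 2-chlorophenyl on a saturated ring carbon. Nothing measured speaks to this change, so compound 3 is expected to stay close to compound 2. The estimate for compound 3 is 1700 nM, between 500 nM and 6000 nM. The expected step of a 1.0-fold lower number from compound 2 to compound 3 (0.01 log units; within the scatter) is therefore none beyond the scatter.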

Compound 3, concentration for 50% growth inhibition: 3180 nM
Compound 3: the middle estimate sits 1.9-fold (0.27 log units) below what was measured, and the stated range covers the measured number.
By their numbers in this assay, from the lowest: compounds 1, 2 and 3 (each within the scatter of the next).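

At this saturated ring carbon, 2-phenylethenyl stands in for 2-chlorophenyl with no change beyond the scatter in this assay, the step being a 1.8-fold higher number from compound 2 to compound 3 (0.26 log units; within the scatter). The same holds against 2-hydroxyphenyl, with a 1.8-fold higher number from compound 1 to compound 3 (0.26 log units; within the scatter), so these three groups, each carrying one six-membered aromatic ring of carbon, cannot be told apart here. No supporting measurement is available to explain this result. What the compounds shown leave open is how this carbon responds to a group without an aromatic ring, such as an amine or a short alkyl chain.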